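From 4-methylphenyl to 3-methylphenyl on the sulfonamide nitrogen

A few compounds are considered here, and "the series" means these few. Any claim that something is new, unique, unknown or untested is made for them only; others in the source may bear on it.

Of the compounds shown here, three have been measured in a functional assay on HeLa cells (Homo sapiens) for inhibition, read by CCK-8 assay, with a stated time of 72 h; on this read-out lower numbers stand for stronger inhibition and higher numbers for weaker inhibition. Compound 1 `O=C(/C=C/c1cccnc1)NCCCCCCc1ccc(S(=O)(=O)Nc2ccccc2)cc1` gives 377 nM, compound 2 `O=C(/C=C/c1cccnc1)NCCCCCc1cccc(S(=O)(=O)Nc2ccccc2)c1` gives 105 nM and compound 3 `Cc1ccc(NS(=O)(=O)c2cccc(CCCCCCNC(=O)/C=C/c3cccnc3)c2)cc1` gives 38.8 nM. Compound 3 thus has the lowest number of the three, and its gaps to compound 2 and to compound 1 both lie beyond the scatter.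

The next compound is compound 4 `Cc1cccc(NS(=O)(=O)c2cccc(CCCCCCNC(=O)/C=C/c3cccnc3)c2)c1`, with 3-methylphenyl in place of 4-methylphenyl on a sulfonamide nitrogen. The two compounds have the same atoms, joined differently. For the measured compounds named here, no measured pair isolates this kind of change, so the data give no direct size for it.

The closest reference is compound 3 at 38.8 nM, and a slightly weaker value is expected, with no step beyond the scatter. The expected step is a 1.3-fold higher number from compound 3 to compound 4 (0.11 log units; within the scatter). In this assay the estimated value for compound 4 is 50 nM, with an expected range from 18 nM to 140 nM.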

Compound 4, half-maximal inhibitory concentration: 65.8 nM
Compound 4: middle estimate off by 1.3-fold (0.12 log units), on the low side; the measured number falls inside the stated range.
By their numbers in this assay, from the lowest: compounds 3, 4 and 2 (each within the scatter of the next, the first and the last beyond it); then compound 1.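

In this assay, for the compounds shown here, the first pair to isolate 3-methylphenyl in place of 4-methylphenyl on the sulfonamide nitrogen gives a 1.7-fold higher number from compound 3 to compound 4 (0.23 log units; within the scatter) and so does not separate the two isomers on this read-out. At this position, the exchange of one methylphenyl for the other is thus tolerated, a reading that rests on this single pair and holds for these two compounds only. No measurement shown here bears on the origin of this small step.

Steps from compound 3 or compound 4 to compound 1 or compound 2 cannot be read, as each of those pairs differs in more than one place, which leaves open whether the methyl contributes at all. Also open, on these data alone, is how a chlorophenyl, a methoxyphenyl or a pyridyl group on the sulfonamide nitrogen would read.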